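Swapping a sulfonamide for a dimethyl amide

The source may report more compounds than this note shows. Statements on the series, on what has been measured and on what is new or still open speak of the compounds shown alone.

Of the compounds shown here, three that share one core have been measured in an in vitro ADME assay on microsomes from liver (Homo sapiens) for metabolic stability; a lower number here means slower removal, a higher number faster removal of the compound. Compound 1 `COc1ccc(-c2cc(-c3ccc(S(=O)(=O)NC4CC4)cc3)cnc2N)cn1` gives 15 mL.min-1.g-1 in this assay. Compound 2 `COc1ccc(-c2cnc(N)c(-c3ccc(OC)nc3)c2)cn1` gives 19.9 mL.min-1.g-1 in this assay. Compound 3 `COc1ccc(-c2cc(-c3cccc(C(N)=O)c3)cnc2N)cn1` returns only a limit of the assay, < 7 mL.min-1.g-1, and no number. Among the two numbers, compound 1 holds the lowest, with compound 2 as its nearest neighbour; the gap between them lies within the usual scatter, so neither can be called the more stable of the two.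

Compound 4 `COc1ccc(-c2cc(-c3ccc(C(=O)N(C)C)cc3)cnc2N)cn1` has not yet been measured. It differs from compound 1 in one place: dimethylcarbamoyl in place of cyclopropylsulfamoyl on an aromatic carbon. For the measured compounds named here, no measured pair in this set makes the same change, so there is no direct guide to how large the step will be. The step from compound 1 to compound 4 is expected to be a 1.1-fold higher number from compound 1 to compound 4 (0.03 log units; within the scatter), which amounts to little or no movement beyond the scatter, with some room for a modest rise in clearance. Compound 4 is therefore estimated at 16 mL.min-1.g-1, with a range running from 6 mL.min-1.g-1 to 40 mL.min-1.g-1.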

Compound 4, intrinsic clearance in microsomes: 11.1 mL.min-1.g-1
Compound 4: middle estimate off by 1.4-fold (0.16 log units), on the high side, within the range that was stated.
By their numbers in this assay, from the lowest: compounds 4, 1 and 2 (each within the scatter of the next). At a limit, below all of these: compound 3.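

The step is a 1.4-fold lower number from compound 1 to compound 4 (0.13 log units; within the scatter) in this assay, so this single pair gives no sign that replacing cyclopropylsulfamoyl with dimethylcarbamoyl, on an aromatic carbon para to a large group, moves clearance beyond ordinary repeat variation. The change alters several features together: the entering group has no sulfur, no ring and no hydrogen-bond donor, yet this pair shows no separable shift in the number, and it cannot say whether any one of those features matters alone or whether their influences offset each other. Compound 3 remains the only compound at a limit of the assay, which is not a number: the limit of < 7 mL.min-1.g-1 in this assay, at which 1 of the 4 values shown sits.

A sulfonamide carrying two methyl groups on its nitrogen, or a cyclopropyl amide, would help separate the contribution of the sulfur-containing link from that of the cyclopropyl ring. Going by these compounds, it also remains open whether a carboxylic acid, an aminomethyl group or a longer alkyl chain at this same position would give a step beyond the scatter, since both groups seen here leave the number in the same narrow band.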